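Growing an amine on the pyrimidine of a urea kinase inhibitor

A few compounds are considered here, and "the series" means these few. Any claim that something is new, unique, unknown or untested is made for them only; others in the source may bear on it.

Measured compounds:
compound 1 `O=C(Nc1ccc(Oc2ccncn2)cc1)Nc1cccc(C(F)(F)F)c1` — 160 nM
compound 2 `CNc1cc(Oc2ccc(NC(=O)Nc3cccc(C(C)(F)F)c3)cc2)ncn1` — 40 nM
compound 3 `CNc1nccc(Oc2ccc(NC(=O)Nc3cccc(C(F)(F)F)c3)cc2)n1` — 50 nM

These three compounds share a urea linked through a diaryl ether to a six-membered aromatic ring bearing two nitrogens, and all were tested in an assay on isolated protein for inhibition of serine/threonine-protein kinase TNNI3K (Homo sapiens); a higher number here means a weaker inhibitor, a lower number a stronger inhibitor. Compound 1 stands highest of the three numbers in this assay; compound 3 gives a lower number, and compound 2 a lower number still.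

Within the data shown here, the one step that can be read directly is a 3.2-fold lower number from compound 1 to compound 3 (0.51 log units; beyond the scatter), a modest gain from adding methylamino on an aromatic carbon of the shared core. Among the measured compounds shown here, compound 2, which carries the same methylamino on the other ring carbon together with a different fluorinated group, shows a value in the same region as compound 3, but no single-change step links it to compound 1.

Compound 4 `C[C@@H](O)CNc1cc(Oc2ccc(NC(=O)Nc3cccc(C(F)(F)F)c3)cc2)ncn1` is not yet measured. It differs from compound 1 by (2-hydroxypropyl)amino in place of hydrogen on an aromatic carbon. For the measured compounds named here, the change resembles the one from compound 1 to compound 3, only with a longer, hydroxylated chain in place of methyl, so a step of similar size in the same direction is expected, with the chain's extra length adding some uncertainty. In this assay compound 4 is therefore estimated at 50 nM, within a range of 20 nM to 130 nM, which corresponds to an expected step of a 3.2-fold lower number from compound 1 to compound 4 (0.51 log units; beyond the scatter).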

Compound 4, half-maximal inhibitory concentration: 63 nM
Beside the measured number, compound 4's estimate is 1.3-fold (0.10 log units) below it; low and high end bracket the measured number.
By their numbers in this assay, from the lowest: compounds 2, 3 and 4 (each within the scatter of the next); then compound 1.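

In this assay, a 2.5-fold lower number from compound 1 to compound 4 (0.40 log units; beyond the scatter) shows that this aromatic carbon, next to the ring nitrogen, can carry a chain as large as (2-hydroxypropyl)amino, with 5 heavy atoms and a defined stereocentre, and the number still falls rather than rises. Among these compounds, the only earlier single change on the core of compound 1, methylamino, gave a 3.2-fold lower number from compound 1 to compound 3 (0.51 log units; beyond the scatter), so two different amine groups in place of hydrogen now point the same way, both beyond the scatter. No measurement here explains the size of either step.

What the hydroxyl adds could be read only against a plain propylamino chain, and what the stereocentre adds only against its mirror-image form. How much further this position can grow would take a longer chain or a ring amine such as morpholine on the same carbon.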